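This account rests on a few compounds, and the source may have more. Where it says the series, first, only, none or still open, it means among the compounds named here.

Measured in an ADME assay on Caco-2 cells (Homo sapiens) for permeability, read by LC-MS, in the apical to basolateral direction, with a stated time of 2 h, tested at 2 uM; a lower number here means that the compound crosses the layer more slowly, a higher number that the compound crosses the layer faster:
- Compound 1 `CC[C@@H](Nc1c(C#N)c(-c2ccc(-c3ccccc3F)cc2)nc2cnccc12)C(N)=O`: 140 nm/s
- Compound 2 `CC[C@@H](Nc1c(C#N)c(-c2ccc(-c3ccc(OC)cc3)cc2)nc2cnccc12)C(N)=O`: 114 nm/s
- Compound 3 `CC[C@@H](Nc1c(C#N)c(-c2ccc(-c3cccc(Cl)c3)cc2)nc2cnccc12)C(N)=O`: 37 nm/s

Compound 3 has the lowest of these numbers, and its gap to each of the others lies beyond the scatter. Replacing 2-fluorophenyl with 3-chlorophenyl gave a 3.8-fold lower number from compound 1 to compound 3 (0.58 log units; beyond the scatter), and replacing 4-methoxyphenyl with 3-chlorophenyl gave a 3.1-fold lower number from compound 2 to compound 3 (0.49 log units; beyond the scatter). Both steps are modest. By contrast, a 1.2-fold lower number from compound 1 to compound 2 (0.09 log units; within the scatter) lies within the scatter.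

Compound 4 `CC[C@@H](Nc1c(C#N)c(-c2ccc(-c3ccc(Cl)cc3)cc2)nc2cnccc12)C(N)=O` keeps the same atoms but has 4-chlorophenyl in place of 3-chlorophenyl on an aromatic carbon. For the measured compounds named here, no measured step moves a chlorine, so the evidence is indirect. Compound 2 also carries its group at the 4 position of the ring, and the step to the 3-chlorophenyl compound was a 3.1-fold lower number from compound 2 to compound 3 (0.49 log units; beyond the scatter). Three compounds establish no pattern, so only a partial recovery is expected, estimated as a 1.8-fold higher number from compound 3 to compound 4 (0.24 log units; within the scatter). For compound 4, the estimated value is 65 nm/s, with an expected range of 30 nm/s to 140 nm/s.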

Compound 4, apparent permeability: 29 nm/s
Estimate against measurement, compound 4: 2.2-fold (0.35 log units) above, outside the stated range (below it).
By their numbers in this assay, from the lowest: compounds 4 and 3 (each within the scatter of the next); then compounds 2 and 1 (each within the scatter of the next).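

In this assay, 4-chlorophenyl in place of 3-chlorophenyl gives a 1.3-fold lower number from compound 3 to compound 4 (0.11 log units; within the scatter), so the low number of compound 3 does not depend on which of these two places on the ring holds the chlorine. For the compounds shown here, the new compound also stays apart from the others: chloro in place of methoxy gives a 3.9-fold lower number from compound 2 to compound 4 (0.59 log units; beyond the scatter), and 4-chlorophenyl in place of 2-fluorophenyl gives a 4.8-fold lower number from compound 1 to compound 4 (0.68 log units; beyond the scatter), so across these four compounds both chlorophenyl compounds hold the low numbers and no compound goes against that. Nothing measured here says what lies behind this link.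

As far as these compounds go, whether the link belongs to chlorine alone remains open. A bromo group, an amine or a carboxylic acid at the same place on the ring, or a plain phenyl ring, could separate a chlorine effect from a wider trend.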